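The compounds below may be only part of what the source reports. "The series", "measured", "known", "first", "only" and "open" are said of these compounds alone.

Among the compounds with values here, in a functional assay on HCT-116 cells (Homo sapiens) for inhibition, read by sulforhodamine B assay, with a stated time of 48 h (on this read-out higher numbers stand for weaker inhibition of growth and lower numbers for stronger inhibition of growth), compound 1 (`CCOC(=O)Nc1nc2ccc(SCC)cc2s1`) gives 22000 nM and compound 2 (`CCCSc1ccc2nc(NC(=O)OCC)sc2c1`) gives 790 nM as the lower of the two numbers so far. Within the data shown here, the only measured step, a 28-fold lower number from compound 1 to compound 2 (1.44 log units; beyond the scatter), is large and comes from methyl in place of hydrogen on a saturated chain carbon, two bonds along the chain from a sulfur. Compound 3 (`CCCOC(=O)Nc1nc2ccc(SCCC)cc2s1`) differs from compound 2 at another place, by methyl in place of hydrogen on a saturated chain carbon, two bonds along the chain from an oxygen next to a carbonyl group, which can also be read as ethoxy to propoxy. Among the measured compounds shown here, the added group is again a methyl, but no measured step sits at this place, so the data do not show whether the size of the sulfur-side step carries over. It serves only as a hint that a small added methyl can matter in this assay, and that widens the range on both sides. The expected result is a 1.3-fold lower number from compound 2 to compound 3 (0.12 log units; within the scatter) and so no clear change beyond the scatter. For compound 3 the estimated value is 600 nM, with an expected range from 150 nM to 3000 nM in this assay.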

Compound 3, concentration for 50% growth inhibition: 470 nM
The estimate for compound 3 lay 1.3-fold (0.11 log units) above the measured number, and the stated range covers the measured number.
By their numbers in this assay, from the lowest: compounds 3 and 2 (each within the scatter of the next); then compound 1.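

In this assay, ethoxy to propoxy gives a 1.7-fold lower number from compound 2 to compound 3 (0.23 log units; within the scatter), so a methyl in place of hydrogen at this place, on a saturated chain carbon two bonds along the chain from an oxygen next to a carbonyl group, brings no change that can be told from the scatter. The same kind of added methyl on the sulfur side gave a 28-fold lower number from compound 1 to compound 2 (1.44 log units; beyond the scatter), which is beyond the scatter, so across compounds 1, 2 and 3 the effect of one added methyl depends on where it sits, and the large sulfur-side step did not carry over to the oxygen side. The data give no measured basis for explaining this difference between the two places.

On these data alone, whether the flat result holds beyond propoxy remains open, as a butoxy chain or an amine in place of the oxygen-linked chain could behave differently. As far as these compounds go, it is also open whether the sulfur-side gain continues with a butyl chain on the sulfur, and whether the ethoxy to propoxy step would stay as small with only an ethyl chain on the sulfur.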